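Piperidine-carboxamide anilides: aryl swap on the ring amine

The source may report more compounds than this note shows. Statements on the series, on what has been measured and on what is new or still open speak of the compounds shown alone.

Measured compounds in a functional assay for antagonist activity at transient receptor potential cation channel subfamily V member 1 (Homo sapiens), read by FLIPR and calcium flux; a higher number here means a weaker inhibitor, a lower number a stronger inhibitor:
compound 1 `O=C1CSc2ccc(NC(=O)C3CCN(c4cc(F)c(F)c(F)c4)CC3)cc2N1` gives 1960 nM
compound 2 `CC(C)c1ccccc1N1CCC(C(=O)Nc2ccc3c(c2)NC(=O)CO3)CC1` gives 180 nM
compound 3 `COC(=O)CC1Oc2ccc(NC(=O)C3CCN(c4cc(F)cc(F)c4)CC3)cc2NC1=O` gives 890 nM

Compound 2 stands lowest of the three values in this assay; both compound 1 and compound 3 give higher numbers, with gaps beyond the scatter, so compound 2 is the strongest inhibitor measured so far.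

Compound 4 `Cc1c(Cl)cccc1N1CCC(C(=O)Nc2ccc3c(c2)NC(=O)CO3)CC1` is not yet measured. It differs from compound 2 by 3-chloro-2-methylphenyl in place of 2-isopropylphenyl on an amine nitrogen in a ring. Going by the values given here, no measured pair isolates a change of this kind, so the direction cannot be read from the numbers at hand. The expected step from compound 2 to compound 4 in this assay is a 1.7-fold higher number from compound 2 to compound 4 (0.22 log units; within the scatter), modest and within or just beyond the scatter. Compound 4 is estimated at 300 nM, with a range from 100 nM to 900 nM.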

Compound 4, half-maximal inhibitory concentration: 100 nM
Estimate against measurement, compound 4: 3.0-fold (0.48 log units) above; the range from low to high includes it.
By their numbers in this assay, from the lowest: compounds 4 and 2 (each within the scatter of the next); then compound 3; then compound 1.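

In this assay, replacing 2-isopropylphenyl with 3-chloro-2-methylphenyl on the ring amine nitrogen gives a 1.8-fold lower number from compound 2 to compound 4 (0.26 log units; within the scatter) and so leaves the two aryl groups unseparated at this position. This is the only pair shown that differs in one place, and it shows that this position accepts a chlorine-bearing aryl group without a change beyond the scatter. Nothing at hand accounts for this result.

Still open, from the compounds shown here alone, is whether an aryl group carrying an amine or a carboxylic acid holds this level on the ring amine. Also open, going by these compounds, is whether 3-chloro-2-methylphenyl gives a similar value on the core of compound 1 or of compound 3.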